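Changing the Aryl Group on the Sulfonyl Sulfur

The source may hold more compounds than are shown below. What is called first, only, known or untested is meant among the compounds shown, and "the series" means these compounds.

Three compounds have been measured in a functional assay on the whole organism (strain Jcl:Sprague-Dawley) for inhibition, with Rattus norvegicus as the target, with stated times of 3 min and 3 h, at a dose of 1 mg/kg by the intravenous route; a higher number here means more inhibition at the dose given (going by the name of the read-out), a lower number less inhibition:

compound 1, `CNCc1cn(S(=O)(=O)c2cccs2)c(-c2cccnc2F)c1F`, 98%
compound 2, `CNCc1cn(S(=O)(=O)c2ccccn2)c(-c2cccnc2F)c1F`, 95%
compound 3, `CNCc1cn(S(=O)(=O)c2ccc(OC)cn2)c(-c2cccnc2F)c1F`, 95%

Compound 2 stands level with compound 3 at the digits shown, the two together the lowest of the three numbers; its nearest neighbour is compound 3, where no change at the digits printed from compound 2 to compound 3 (within the scatter), and its furthest is compound 1, from which a number 3 percentage points lower from compound 1 to compound 2 (within the scatter). Compound 4, `CNCc1cn(S(=O)(=O)c2cncc(F)c2)c(-c2cccnc2F)c1F`, differs from compound 2 in one place: 5-fluoropyridin-3-yl in place of pyridin-2-yl on a sulfonyl sulfur. Among the measured compounds shown here, two measured steps bear on such a change of the aryl group on the sulfonyl sulfur: a number 3 percentage points lower from compound 1 to compound 2 (within the scatter) and a number 3 percentage points lower from compound 1 to compound 3 (within the scatter), both within the scatter. A step of a number 1 percentage points lower from compound 2 to compound 4 (within the scatter) is therefore expected, none beyond the scatter. Compound 4 is estimated to give 94%, with a range from 82% to 99%.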

Compound 4, a percentage reported as inhibition, in the whole organism at one dose (the size of the read-out at that dose, not a potency): 99%
Estimate against measurement, compound 4: 5 percentage points below; the range from low to high includes it.
By their numbers in this assay, from the lowest: compounds 2, 3, 1 and 4 (each within the scatter of the next).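

In this assay the sulfonyl sulfur takes a 5-fluoropyridin-3-yl group as readily as the earlier aryl groups: there is a number 4 percentage points higher from compound 2 to compound 4 (within the scatter) and a number 4 percentage points higher from compound 3 to compound 4 (within the scatter) and also a number 1 percentage points higher from compound 1 to compound 4 (within the scatter) in this set. All four aryl groups, the fluorine-bearing one included, thus give values within the scatter of one another. Nothing measured here accounts for these values.

As far as these compounds go, it remains open whether any group on the sulfonyl sulfur would lower the inhibition at this dose. A methyl group, or an aryl group carrying an amine or a carboxylic acid, would put that to the test.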